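The compounds below may be only part of what the source reports. "The series", "measured", "known", "first", "only" and "open" are said of these compounds alone.

Compound 2 `Cc1ccc2nc(N3CCCc4ccc(F)cc4C3)cc(NCCN)c2c1` stands only as a limit: in an ADME assay on HEp-2 cells (Homo sapiens) for cytotoxicity, read by CCK-8 assay, with a stated time of 5 days (a lower number here means that less compound is tolerated, a higher number that more compound is tolerated), compound 2 gives > 3200 nM, which is a limit of the assay and not a number (the limit of > 3200 nM in this assay, at which 1 of the 2 values shown sits). Compound 1 `Cc1ccc2nc(N3CCCc4ccccc4C3)cc(NCCN)c2c1` gives 9400 nM, so the step that the limit leaves unreadable from compound 1 to compound 2 cannot be read. Compound 3 `Cc1ccc2nc(N3CCCc4ccc(F)cc4C3)cc(NC(C)(C)CN)c2c1` differs from compound 2 by 1-(aminomethyl)-1-methylethyl in place of 2-aminoethyl on a nitrogen on an aromatic ring. Among the compounds with values here, no measured step touches this change, and the one measured step concerns a different place, so no shift beyond the scatter is expected. Compound 3 is therefore estimated at 8000 nM, within 2500 nM to 25000 nM. The expected step is a step that the limit leaves unreadable from compound 2 to compound 3.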

Compound 3, half-maximal cytotoxic concentration: 25000 nM
Beside the measured number, compound 3's estimate is 3.1-fold (0.49 log units) below it, and the stated range covers the measured number.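

No step can be read from compound 2 to compound 3, because compound 2 stands only as a limit: the limit of > 3200 nM in this assay, at which 1 of the 3 values shown sits.

The compounds shown leave open how much either change, fluoro in place of hydrogen or 1-(aminomethyl)-1-methylethyl in place of 2-aminoethyl, alters how well the cells tolerate these compounds.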